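Methylation of the ring amine on a methylthio purine nucleotide

A few compounds are considered here, and "the series" means these few. Any claim that something is new, unique, unknown or untested is made for them only; others in the source may bear on it.

Three purine bisphosphates have been measured. Compound 1 `CNc1nc(I)nc2c1ncn2[C@H]1C[C@H](OP(=O)(O)O)[C@@H](COP(=O)(O)O)O1` gives 891 nM in a functional assay on cell membranes for antagonist activity at P2Y purinoceptor 1 (Meleagris gallopavo); on this read-out lower numbers stand for stronger inhibition and higher numbers for weaker inhibition. For compound 2 `CONc1ncnc2c1ncn2[C@H]1C[C@H](OP(=O)(O)O)[C@@H](COP(=O)(O)O)O1` this assay reports only a limit, > 100000 nM. Going by the values given here, compound 3 `CSc1nc(N)c2ncn([C@H]3C[C@H](OP(=O)(O)O)[C@@H](COP(=O)(O)O)O3)c2n1` gives 1890 nM, the higher of the two numbers, with compound 1 as the nearest value beyond the scatter; compounds 1 and 3 differ in more than one place, so no single step links them. Compound 4 `CNc1nc(SC)nc2c1ncn2[C@H]1C[C@H](OP(=O)(O)O)[C@@H](COP(=O)(O)O)O1` has not yet been measured; it differs from compound 3 by methyl in place of hydrogen on a nitrogen on an aromatic ring. He expects the step from compound 3 to compound 4 to be modest and downward, a 2.4-fold lower number from compound 3 to compound 4 (0.37 log units; beyond the scatter), since compound 1, which also carries methylamino, gives 891 nM. His estimate for compound 4 is 800 nM, between 250 nM and 2600 nM.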

Compound 4, half-maximal inhibitory concentration: 362 nM
Compound 4: the middle estimate sits 2.2-fold (0.34 log units) above what was measured; low and high end bracket the measured number.
By their numbers in this assay, from the lowest: compound 4; then compound 1; then compound 3. At a limit, above all of these: compound 2.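

In this assay, going by these compounds alone, methyl in place of hydrogen on a nitrogen on an aromatic ring gives a 5.2-fold lower number from compound 3 to compound 4 (0.72 log units; beyond the scatter), the first single-place reading of amino to methylamino. With methylamino held, methylsulfanyl in place of iodo on an aromatic carbon gives a 2.5-fold lower number from compound 1 to compound 4 (0.39 log units; beyond the scatter), so the number also responds to the group at that second place.

Going by these compounds, whether ethyl on that nitrogen, or ethylsulfanyl in place of methylsulfanyl, would lower the number further remains open. Nothing measured here gives a reason for either step.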